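The compounds below may be only part of what the source reports. "The series", "measured", "known", "first", "only" and "open" are said of these compounds alone.

Compound 1 (`CO[C@@H](c1ccccc1)[C@H]1O[C@@H]2CC(=O)O[C@@H]2[C@H]1O`) gives 11500 nM
Compound 2 (`CO[C@@H]1[C@H]2OC(=O)C[C@H]2O[C@@H]1C(O)(c1ccccc1)c1ccccc1`) gives 28700 nM

In a functional assay on K562 cells (Homo sapiens) for inhibition, read by MTT assay, with a stated time of 72 h (on this read-out lower numbers stand for stronger inhibition and higher numbers for weaker inhibition), compound 1 has the lower of the two numbers, and its gap to compound 2 lies beyond the usual scatter. Compound 3 (`CO[C@H](c1ccccc1)[C@H]1O[C@@H]2CC(=O)O[C@@H]2[C@H]1O`) has not yet been measured. Going by the values given here, its only difference from compound 1 is one of configuration as drawn (the two compounds have the same atoms and bonds and differ only in configuration as drawn: 1 of 5 stereo elements differ; a stereocentre at a saturated chain carbon is drawn S in compound 1 and R in compound 3): a stereocentre at a saturated chain carbon is drawn S in compound 1 and R in compound 3. Among the compounds with values here, no measured pair shows what this change alone does, so only a modest move towards weaker inhibition is expected (a 1.3-fold higher number from compound 1 to compound 3 (0.12 log units; within the scatter)). Compound 3 is estimated at 15000 nM (range 6000 nM to 40000 nM).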

Compound 3, half-maximal inhibitory concentration: 7950 nM
Beside the measured number, compound 3's estimate is 1.9-fold (0.28 log units) above it; low and high end bracket the measured number.
By their numbers in this assay, from the lowest: compounds 3 and 1 (each within the scatter of the next); then compound 2.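

Turning the stereocentre at the saturated chain carbon from S to R gives a 1.4-fold lower number from compound 1 to compound 3 (0.16 log units; within the scatter) in this assay. Going by these compounds alone, this is the first direct reading of that change alone, and it shows that this assay does not separate the two configurations as drawn. The reading speaks for that stereocentre alone because nothing else separates the pair: the fact that compounds 1 and 3 differ only in the configuration as drawn.

Still open, from the compounds shown here alone, is how an amine or a longer chain on that same carbon would read in this assay. Going by these compounds, whether the configuration would then begin to matter also remains unknown.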